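A few compounds are considered here, and "the series" means these few. Any claim that something is new, unique, unknown or untested is made for them only; others in the source may bear on it.

Compound 1 `O=C(N/N=C/c1cccc(F)c1)c1cnccn1` and compound 3 `O=C(N/N=C/c1cccc(Br)c1)c1cnccn1` share a core and differ in one group; how the core of compound 2 `O=C(N/N=C/c1ccc(F)cc1)c1cnccn1` differs from that of compound 1 is not broken down here. In an ADME assay on J774 cells (Mus musculus) for cytotoxicity, read by MTT assay, with a stated time of 48 h, tested at 100 ug/mL (on this read-out lower numbers stand for a stronger effect and higher numbers for a weaker effect at the one concentration tested), compound 1 gives 46%, compound 2 gives 69% and compound 3 gives 100%. The change bromo in place of fluoro on an aromatic carbon made a step of a number 54 percentage points higher from compound 1 to compound 3 (beyond the scatter). Compound 4 `O=C(N/N=C/c1ccc(Br)cc1)c1cnccn1` carries the same kind of change, (bromo in place of fluoro on an aromatic carbon), but where the group in compound 3 sits meta to a large group, in compound 4 it sits para to a large group. Because of a number 54 percentage points higher from compound 1 to compound 3 (beyond the scatter), the step from compound 2 to compound 4 in this assay is expected to be a number 24 percentage points higher from compound 2 to compound 4 (beyond the scatter), though the read-out cannot rise far past compound 3. Compound 4 is therefore estimated at 93%, between 78% and 100%.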

Compound 4, a percentage reported as activity, at one concentration (the size of the read-out at that concentration, not a potency): 100%
Estimate against measurement, compound 4: 7 percentage points below; low and high end bracket the measured number.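

In this assay the change to bromo from fluoro on the second core gave a number 31 percentage points higher from compound 2 to compound 4 (beyond the scatter). The direction of the change thus carried over from one core to the other, but its size did not: the same change on two cores in this assay, a number 54 percentage points higher (beyond the scatter) from compound 1 to compound 3 and a number 31 percentage points higher (beyond the scatter) from compound 2 to compound 4, 23 percentage points apart, beyond the scatter of two such steps

Compound 3 gives 100% and compound 4 gives 100%, so both steps end at the same number, and two cores cannot show how the change would behave on any other core in this series. The compounds shown carry only fluoro or bromo on that ring. They leave open what chloro, methoxy, an amine or a carboxylic acid in the same place would give in this assay.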